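From Benzyl to Carbonyl on a Ring Nitrogen

The compounds below may be only part of what the source reports. "The series", "measured", "known", "first", "only" and "open" are said of these compounds alone.

Compound 1 `Fc1ccc(CN2CCC(NCCSC(c3ccc(F)cc3)c3ccc(F)cc3)CC2)cc1` was tested in an ADME assay on microsomes from liver (Rattus norvegicus) for metabolic stability, read by LC-MS, using NADPH, tested at 10 uM; a higher number here means that more of the compound is left, a lower number that less of the compound is left. In this assay compound 1 gives 100%. Compound 2 `[O-][S+](CCNC1CCN(CC(O)Cc2ccccc2)CC1)C(c1ccc(F)cc1)c1ccc(F)cc1` shares much of the same framework, and in this assay compound 2 gives 100%. The two values are level at the digits shown, so compound 1 stands alongside compound 2 rather than apart from it, and neither can be called the more stable of the pair.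

Compound 3 `O=C(c1ccc(F)cc1F)N1CCC(NCCSC(c2ccc(F)cc2)c2ccc(F)cc2)CC1` has not yet been measured. Compared with compound 1, it carries (2,4-difluorophenyl)carbonyl in place of 4-fluorobenzyl on an amine nitrogen in a ring. Among the measured compounds shown here, no measured pair shows what this kind of swap does, so the size of the step cannot be read from the data. Since compound 1 sits at 100%, there is almost no room upward. A step of a number 5 percentage points lower from compound 1 to compound 3 (within the scatter) that stays within the usual scatter is expected. Compound 3 is therefore expected to give 95%, with a likely range from 75% to 100%.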

Compound 3, percent of the compound remaining: 100%
Compound 3: middle estimate off by 5 percentage points, on the low side; the range from low to high includes it.
By their numbers in this assay, from the lowest: compounds 1, 2 and 3 (each within the scatter of the next).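

In this assay, among the compounds shown here, the read-out shows no change at the digits printed from compound 1 to compound 3 (within the scatter) when (2,4-difluorophenyl)carbonyl takes the place of 4-fluorobenzyl on an amine nitrogen in a ring, the only measured swap at this position. This ring nitrogen can therefore carry a carbonyl-linked group, with one more hydrogen-bond acceptor and more heavy atoms, without any loss showing here, although a read-out already at the top of its scale could not show a gain. Nothing measured explains why the value holds at this position.

The step swaps in the carbonyl and a second fluorine together, and the compounds shown do not separate the two. Going by these compounds, whether a sulfonyl group or a longer chain on this ring nitrogen would keep the compound at this level stays open.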